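The compounds below may be only part of what the source reports. "The series", "measured", "known", "first", "only" and "open" are said of these compounds alone.

Working notes on the series. Among the measured compounds shown here, compound 1 `O=C(c1cn[nH]c1)N1CCC(C(=O)N2N=CCC2c2ccccc2)CC1` gives 0.417 h in an ADME assay on the whole organism (Rattus norvegicus) for metabolic stability, at a dose of 1 mg/kg by the intravenous route (a higher number here means that the compound lasts longer, a lower number that the compound disappears faster), and holds the lower of the two numbers so far. Compound 2 `CC(=O)N1CCC(C(=O)N2N=CC[C@H]2c2ccccc2)CC1` gives 0.85 h in this assay and the gap between the two lies beyond the usual scatter. For the measured compounds named here, these two compounds do not form a comparison at a single place, so no measured step is available to guide the next one.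

Compound 3 `O=C(c1c[nH]nn1)N1CCC(C(=O)N2N=CCC2c2ccccc2)CC1` differs from compound 1 by one change (1H-1,2,3-triazol-4-yl in place of 1H-pyrazol-4-yl on a carbonyl carbon) with 1H-1,2,3-triazol-4-yl in place of 1H-pyrazol-4-yl on a carbonyl carbon. The rest of the structure stays as it is, and one five-membered aromatic ring replaces another with no net charge on either. Going by the values given here, with no precedent for this replacement, the expectation rests on compound 1 at 0.417 h and on the structural change alone. The estimated 1.1-fold higher number from compound 1 to compound 3 (0.03 log units; within the scatter) is expected to stay within the usual scatter, with no firm direction. For compound 3 the estimated half-life is 0.45 h (0.22 h to 0.9 h as the expected range).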

Compound 3, half-life: 0.417 h
Beside the measured number, compound 3's estimate is 1.1-fold (0.03 log units) above it, within the range that was stated.
By their numbers in this assay, from the lowest: compounds 1 and 3 (each within the scatter of the next); then compound 2.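

In this assay, among the compounds shown here, placing 1H-1,2,3-triazol-4-yl in place of 1H-pyrazol-4-yl on a carbonyl carbon gives no change at the digits printed from compound 1 to compound 3 (within the scatter), and this is the first measured step at this position. On the core of compound 1, the read-out therefore does not separate these two five-membered aromatic rings, even though they differ in their hetero atoms and hydrogen-bond acceptors and neither carries a net charge. No supporting measurement bears on why the half-life does not separate these two rings.

For the compounds shown here, this single step covers only two uncharged five-membered aromatic rings on the carbonyl carbon, so it cannot show how far the result extends to other kinds of group at this position, such as a pyridine ring, a ring carrying an amine or one carrying a carboxylic acid. Going by these compounds alone, it also says nothing about changes elsewhere on the shared core, where the series so far offers no comparison at a single place.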